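Phenyl for piperidin-1-yl on a carbonyl carbon

A few compounds are considered here, and "the series" means these few. Any claim that something is new, unique, unknown or untested is made for them only; others in the source may bear on it.

In an ADME assay on microsomes from liver (Mus musculus) for metabolic stability, read by mass spectrometry, using NADPH, tested at 1.5 uM (a higher number here means that the compound lasts longer, a lower number that the compound disappears faster), compound 1 (`O=C(Nc1ccc2sc(-c3ccc(F)c(F)c3)nc2c1)N1CCCC1`) gives 0.233 h, compound 2 (`O=C(Nc1ccc2sc(-c3ccccc3)nc2c1)N1CCCC1`) gives 0.3 h and compound 3 (`O=C(Nc1ccc2oc(-c3ccccc3)nc2c1)N1CCCCC1`) gives 0.183 h, so compound 3 lies within the scatter of both others. Compound 4 (`O=C(Nc1ccc2oc(-c3ccccc3)nc2c1)c1ccccc1`) puts phenyl in place of piperidin-1-yl on a carbonyl carbon. Among the measured compounds shown here, the only measured step, a 1.3-fold higher number from compound 1 to compound 2 (0.11 log units; within the scatter), concerns another place, an aromatic carbon, and offers weak guidance. For the measured compounds named here, no measured pair tests this swap directly, and the three values so far sit close together. The expected step is therefore a 1.1-fold higher number from compound 3 to compound 4 (0.04 log units; within the scatter), nothing beyond the scatter. Compound 4 is estimated at 0.2 h, with an expected range from 0.1 h to 0.4 h.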

Compound 4, half-life: 0.283 h
For compound 4 the middle estimate is 1.4-fold (0.15 log units) below the measured one; the range from low to high includes it.
By their numbers in this assay, from the lowest: compounds 3, 1, 4 and 2 (each within the scatter of the next).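

Phenyl in place of piperidin-1-yl on a carbonyl carbon gives a 1.5-fold higher number from compound 3 to compound 4 (0.19 log units; within the scatter) in this assay. This place therefore takes an aromatic ring of carbon only instead of a non-aromatic ring without a shift beyond the scatter. Read one bond further out, benzoyl can stand where (piperidin-1-yl)carbonyl stood, so the ring nitrogen is not needed to keep this number within the scatter. On these data alone, whether morpholin-4-yl, a carboxylic acid or a longer alkyl chain on this carbonyl carbon would move the half-life beyond the scatter stays open. Nothing available explains the result.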